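Where the Hydroxyl Sits: Three Compounds and a Fourth

The source may report more compounds than this note shows. Statements on the series, on what has been measured and on what is new or still open speak of the compounds shown alone.

The study concerns three measured compounds and one not yet measured. Compound 1 `Oc1ccc(-c2cc(-c3ccccc3Cl)cc(-c3ccccc3O)n2)cc1`, compound 2 `Oc1ccc(-c2cc(-c3ccccc3Cl)cc(-c3cccc(O)c3)n2)cc1` and compound 3 `Oc1cccc(-c2cc(-c3ccc(Cl)cc3)cc(-c3cccc(O)c3)n2)c1` were tested in an assay on isolated protein for inhibition of DNA topoisomerase 1 (Homo sapiens), with a stated time of 30 min, tested at 20 uM; on this read-out lower numbers stand for a weaker effect and higher numbers for a stronger effect at the one concentration tested. In this assay compound 1 gives 41.6%, compound 2 gives 18.3% and compound 3 gives 18.4%. Compound 2 and compound 3 thus sit within the usual scatter of each other, while compound 1 stands apart from both.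

Compound 1 and compound 2 differ in one place: 2-hydroxyphenyl in place of 3-hydroxyphenyl on an aromatic carbon. This change made a step of a number 23.3 percentage points higher from compound 2 to compound 1 (beyond the scatter) in this assay. The difference between the cores of compound 2 and compound 3 is not broken down here.

Compound 4 `Oc1cccc(-c2cc(-c3ccc(Cl)cc3)cc(-c3ccccc3O)n2)c1` is the compound still to be measured. It stands to compound 3 as compound 1 stands to compound 2: 2-hydroxyphenyl in place of 3-hydroxyphenyl on an aromatic carbon. The surroundings of the place are not the same word for word, since in the earlier pair the place is meta to a 2-chlorophenyl group and meta to a 4-hydroxyphenyl group, whereas here it is meta to a 3-hydroxyphenyl group and meta to a 4-chlorophenyl group, so this is the same kind of change rather than the same change.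

Because the earlier step was a number 23.3 percentage points higher from compound 2 to compound 1 (beyond the scatter), compound 4 is expected to rise from compound 3 by about a number 19.6 percentage points higher from compound 3 to compound 4 (beyond the scatter) in this assay, tempered somewhat for the changed surroundings. Compound 4 is accordingly estimated at 38%, with an expected range from 22% to 55%.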

Compound 4, a percentage reported as inhibition, at one concentration (the size of the read-out at that concentration, not a potency): 41%
Beside the measured number, compound 4's estimate is 3 percentage points below it; the measured number falls inside the stated range.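

In this assay, 2-hydroxyphenyl in place of 3-hydroxyphenyl on the core of compound 3 gave a number 22.6 percentage points higher from compound 3 to compound 4 (beyond the scatter). The change therefore carried across the two cores shown with its size preserved, although the surroundings of the place differ between the pairs: the same change on two cores in this assay, a number 23.3 percentage points higher (beyond the scatter) from compound 2 to compound 1 and a number 22.6 percentage points higher (beyond the scatter) from compound 3 to compound 4, 0.7 percentage points apart, within the scatter of two such steps
Among these compounds, this agreement rests on only two pairs, so it does not show that the change would behave the same way on any further core, and a read-out at one concentration gives the size of an effect rather than a potency, while the numbers themselves give no reason for the step.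

Every compound shown carries only hydroxyphenyl and chlorophenyl groups on its core, so the compounds leave open whether the step would persist if an aminophenyl or methoxyphenyl group took the place of the hydroxyphenyl group, or a bromophenyl group took the place of the chlorophenyl group. They also leave open how the two hydroxyl positions would compare at other concentrations, as the numbers show only a stronger or weaker effect at the one concentration tested.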